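The compounds below may be only part of what the source reports. "The series", "measured", "known", "first", "only" and "open" are said of these compounds alone.

Compound 1 `C=C(C(=O)c1ccc(OC)cc1)C(OC(=O)c1ccccc1)c1ccccc1F`: 73700 nM
Compound 2 `C=C(C(=O)c1ccc(OC)cc1)C(OC(=O)c1ccccc1)c1c(F)c(F)c(F)c(F)c1F`: 32100 nM

For the measured compounds named here, in a functional assay on A549 cells (Homo sapiens) for inhibition, read by XTT assay, with a stated time of 48 h (a higher number here means a weaker inhibitor, a lower number a stronger inhibitor), compound 2 gives 32100 nM, the lower of the two numbers so far, which makes it the stronger inhibitor of this pair. The next compound, compound 3 `C=C(C(=O)c1ccc(OC)cc1)C(OC(=O)c1ccccc1)c1ccccc1Cl`, puts 2-chlorophenyl in place of 2,3,4,5,6-pentafluorophenyl on the saturated chain carbon: 2-chlorophenyl in place of 2,3,4,5,6-pentafluorophenyl on a saturated chain carbon bound to a double-bonded chain carbon and an oxygen next to a carbonyl group. Going by the values given here, only one measured step bears on this change: a 2.3-fold lower number from compound 1 to compound 2 (0.36 log units; beyond the scatter), a modest step. Among the compounds with values here, the 2-chlorophenyl group carries a single halogen, as the 2-fluorophenyl group of compound 1 does, but no measured compound contains chlorine, so this comparison is only a rough guide. A modest step to a higher number is therefore expected, reversing much of the step seen from 73700 nM for compound 1. The expected change is a 2.0-fold higher number from compound 2 to compound 3 (0.31 log units; beyond the scatter). For compound 3, the estimated value is 65000 nM, with an expected range of 30000 nM to 140000 nM.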

Compound 3, half-maximal inhibitory concentration: 30500 nM
For compound 3 the middle estimate is 2.1-fold (0.33 log units) above the measured one, within the range that was stated.
By their numbers in this assay, from the lowest: compounds 3 and 2 (each within the scatter of the next); then compound 1.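

In this assay the exchange on the saturated chain carbon gives a 1.1-fold lower number from compound 2 to compound 3 (0.02 log units; within the scatter), so the 2-chlorophenyl group and the 2,3,4,5,6-pentafluorophenyl group cannot be told apart here. Replacing fluoro with chloro on an aromatic carbon gives a 2.4-fold lower number from compound 1 to compound 3 (0.38 log units; beyond the scatter), a modest step. The first pair alone could suggest that the number falls only as more fluorine is added, but compound 3 goes against that reading, since it matches compound 2 with a single halogen on the ring. Nothing available explains why these two groups give such similar results.

On these data alone, whether a plain phenyl group with no halogen would sit with compound 1 or with compounds 2 and 3 remains open. So does the outcome with bromo in place of chloro, or with an amine on the ring.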